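A few compounds are considered here, and "the series" means these few. Any claim that something is new, unique, unknown or untested is made for them only; others in the source may bear on it.

Measured compounds: compound 1 `S=C(Nc1ccccc1)N1N=C(c2ccc(Br)cc2)CC1c1ccc2c(c1)OCCO2` gives 470 nM; compound 2 `S=C(Nc1ccccc1)N1N=C(c2ccccc2Br)CC1c1ccc2c(c1)OCCO2` gives > 200000 nM; compound 3 `COc1ccccc1C1=NN(C(=S)Nc2ccccc2)C(c2ccc3c(c2)OCCO3)C1` gives 20300 nM.

All three share one core and differ only in the aryl group on the carbon with a double bond to nitrogen. In a functional assay on A-375 cells (Homo sapiens) for antiproliferative activity, read by MTT assay, with a stated time of 48 h (on this read-out higher numbers stand for weaker inhibition of growth and lower numbers for stronger inhibition of growth), compound 3 gives 20300 nM, the highest of the two numbers reported; the nearest is compound 1, and the step of a 43-fold higher number from compound 1 to compound 3 (1.64 log units; beyond the scatter) is large. The value of compound 2 is a limit of this assay, not a number, as the entry the limit of > 200000 nM in this assay, at which 1 of the 3 values shown sits, shows.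

Compound 4 `S=C(Nc1ccccc1)N1N=C(c2ccc(Cl)c(Cl)c2)CC1c1ccc2c(c1)OCCO2` has not yet been measured. The change is 3,4-dichlorophenyl in place of 2-methoxyphenyl on a carbon with a double bond to nitrogen. Going by the values given here, two measured steps bear on it. The step of a 43-fold higher number from compound 1 to compound 3 (1.64 log units; beyond the scatter) shows that moving from 4-bromophenyl to 2-methoxyphenyl raised the number strongly, and the step of an at least 420-fold higher number from compound 1 to compound 2 (2.62 log units; beyond the scatter) shows that 2-bromophenyl in place of 4-bromophenyl raised it beyond what this assay reports. Compound 4 carries a 3,4-dichlorophenyl, which returns a halogen pattern closer to that of compound 1 than to compound 3. A large drop in the number is therefore expected, a 25-fold lower number from compound 3 to compound 4 (1.40 log units; beyond the scatter). Compound 4 is estimated at 800 nM in this assay, within a range from 200 nM to 6000 nM.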

Compound 4, concentration for 50% growth inhibition: 41900 nM
For compound 4 the middle estimate is 52-fold (1.72 log units) below the measured one, and the stated range ends below it.
By their numbers in this assay, from the lowest: compound 1; then compound 3; then compound 4. At a limit, above all of these: compound 2.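

The low number of compound 1 does not follow from simply having halogen on this aryl group: the 3,4-dichlorophenyl of compound 4 gives an 89-fold higher number from compound 1 to compound 4 (1.95 log units; beyond the scatter), so among the compounds shown, only the 4-bromophenyl gives a low number, and compounds 2 and 4 both carry halogen and go against any rule that halogen is enough. Exchanging the 2-methoxyphenyl for the 3,4-dichlorophenyl gives a 2.1-fold higher number from compound 3 to compound 4 (0.31 log units; beyond the scatter), a modest step, so in this assay this halogen-bearing ring offers no gain over the methoxy-bearing one. Moving to compound 4 from the 2-bromophenyl gives an at least 4.7-fold lower number from compound 2 to compound 4 (0.67 log units; beyond the scatter), and this step starts from a limit of the assay, not a number: the limit of > 200000 nM in this assay, at which 1 of the 4 values shown sits.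

The compounds shown leave open whether the 4-bromophenyl works through the bromine itself or through having a single group at that place on the ring, a question that a 4-chlorophenyl, a 4-methoxyphenyl or a 3-bromophenyl could help to settle. They also leave open how an amine or a carboxylic acid on this aryl group would behave, and what changes elsewhere on the shared core would do.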